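This account rests on a few compounds, and the source may have more. Where it says the series, first, only, none or still open, it means among the compounds named here.

Three compounds share one core and differ only at one aromatic carbon. Compound 1 `Cc1cc(Cc2ccccc2)c(O)c2ccccc12` carries a methyl there and in an assay on RBL-1 cells with Polyunsaturated fatty acid 5-lipoxygenase (Rattus norvegicus) as the target (on this read-out lower numbers stand for stronger inhibition and higher numbers for weaker inhibition), compound 1 gives 20 nM. Compound 2 `Oc1c(Cc2ccccc2)cc(-c2ccccc2)c2ccccc12` carries a phenyl, and in this assay compound 2 gives 56 nM, a step of a 2.8-fold higher number from compound 1 to compound 2 (0.45 log units; beyond the scatter). Compound 3 `CC(=O)c1cc(Cc2ccccc2)c(O)c2ccccc12` carries an acetyl, and in this assay compound 3 gives 510 nM, which is the highest of the three numbers; the step of a 26-fold higher number from compound 1 to compound 3 (1.41 log units; beyond the scatter) and the step of a 9.1-fold higher number from compound 2 to compound 3 (0.96 log units; beyond the scatter) both lie beyond the scatter. Compound 4 `O=C(O)c1cc(Cc2ccccc2)c(O)c2ccccc12` is not yet measured; it differs from compound 3 by hydroxy in place of methyl on a carbonyl carbon. Among the measured compounds shown here, no measured step alters the acetyl itself, so the pair brings no direct guide. The two steps ending at compound 3 show that this position moves the number strongly, and the further change is expected to move it again rather than leave it within the scatter. Compound 4 is therefore estimated at 1500 nM, with a range from 400 nM to 6000 nM, a step of a 2.9-fold higher number from compound 3 to compound 4 (0.47 log units; beyond the scatter) that is expected to run toward weaker inhibition.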

Compound 4, half-maximal inhibitory concentration: 5800 nM
Beside the measured number, compound 4's estimate is 3.9-fold (0.59 log units) below it; the range from low to high includes it.
By their numbers in this assay, from the lowest: compound 1; then compound 2; then compound 3; then compound 4.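

Keeping the carbonyl and changing only the group on it still shifts the result strongly in this assay, with an 11-fold higher number from compound 3 to compound 4 (1.06 log units; beyond the scatter) for hydroxy in place of methyl, so this position responds to a change one atom further out than the earlier steps showed. Carboxy also extends the range at this aromatic carbon, with a 100-fold higher number from compound 2 to compound 4 (2.02 log units; beyond the scatter) against phenyl and a 290-fold higher number from compound 1 to compound 4 (2.46 log units; beyond the scatter) against methyl, and the four compounds now run in the order methyl, phenyl, acetyl, carboxy, with compound 4 the weakest. No supporting measurement accounts for the size of these shifts.

The compounds shown leave open whether a methyl ester or a primary amide on the same carbonyl carbon would behave like the acetyl or the carboxy. They also leave open how an amine or a longer alkyl chain on this aromatic carbon would compare with the methyl of compound 1.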